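The compounds below may be only part of what the source reports. "The series", "measured", "known", "first", "only" and "open" are said of these compounds alone.

Measured compounds:
- compound 1, `Cc1cc(OCc2c(-c3c(Cl)ccc(=O)n3C)noc2C(C)C)ccc1-c1ccc2c(C(=O)O)cn(C)c2c1`: in a functional assay for agonist activity at Bile acid receptor (Homo sapiens), read by a luciferase reporter (on this read-out higher numbers stand for an effect only at larger amounts of compound and lower numbers for an effect already at smaller amounts), compound 1 gives 4000 nM
- compound 2, `COc1ccc(Cl)c(-c2noc(C(C)C)c2COc2ccc(-c3ccc4c(C(=O)O)cn(C)c4c3)c(C)c2)n1`: in this assay compound 2 gives 2000 nM

Compound 2 has the lowest of the two numbers, but its step from compound 1 is small: a 2.0-fold lower number from compound 1 to compound 2 (0.30 log units; within the scatter). The two compounds are therefore indistinguishable on this read-out.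

Compound 3, `Cc1cc(OCc2c(-c3c(Cl)cn(C)c(=O)c3Cl)noc2C(C)C)ccc1-c1ccc2c(C(=O)O)cn(C)c2c1`, is built from compound 2 by one exchange: a group of 10 heavy atoms (6 carbon, 1 nitrogen, 1 oxygen, 2 chlorine; one six-membered aromatic ring with 1 hetero atom) in place of a group of 9 heavy atoms (6 carbon, 1 nitrogen, 1 oxygen, 1 chlorine; one six-membered aromatic ring with 1 hetero atom), on an aromatic carbon. Going by the values given here, the only measured step bearing on this change is the one from compound 1 to compound 2, which swapped a group of the same size at the same place and stayed within the scatter. Compound 3 carries a group of similar size at that place, so no step beyond the scatter is expected in this assay, in either direction; the estimated step is a 1.5-fold higher number from compound 2 to compound 3 (0.18 log units; within the scatter). Compound 3 is expected to give about 3000 nM, within a range from 1000 nM to 9000 nM.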

Compound 3, half-maximal effective concentration: 12000 nM
Compound 3: middle estimate off by 4.0-fold (0.60 log units), on the low side; measured number above the stated range.
By their numbers in this assay, from the lowest: compounds 2 and 1 (each within the scatter of the next); then compound 3.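

Compound 1 and compound 2 made this place on the five-membered ring look forgiving, but in this assay it does respond to the choice of six-membered ring, with a 6.0-fold higher number from compound 2 to compound 3 (0.78 log units; beyond the scatter) and a 3.0-fold higher number from compound 1 to compound 3 (0.48 log units; beyond the scatter). The ring that enters in compound 3 is only slightly larger, with two chlorines where the others carry one, so a small change in size here can still move the number beyond the scatter. Nothing in the available data explains this shift.

Compound 3 differs from compound 1 and from compound 2 in more than an added chlorine, so the shown compounds do not separate the effect of the second chlorine from that of the rest of the ring's arrangement. From the compounds shown here alone, how this place would respond to a ring bearing fluorine instead of either chlorine also remains open.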